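The compounds below may be only part of what the source reports. "The series", "measured", "known", "first", "only" and "open" are said of these compounds alone.

Of the compounds shown here, two have so far been measured in a functional assay on K562 cells (Homo sapiens) for antiproliferative activity, read by CCK-8 assay, with a stated time of 72 h; on this read-out higher numbers stand for weaker inhibition of growth and lower numbers for stronger inhibition of growth. Compound 1 `CCC1C(=O)N(C)c2cnc(Nc3ccc(S(=O)(=O)NCC(C)C)cc3)nc2N1c1ccn(C)n1` gives 7300 nM in this assay, the higher of the two numbers. Compound 2 `CC[C@@H]1C(=O)N(C)c2cnc(-n3ccc4cc(C(=O)NC)ccc43)nc2N1C1CCCC1` gives 705 nM in this assay, a lower number, and the gap between the two is beyond the usual scatter; since these two structures differ in several places at once, the gap cannot be tied to any single change. Compound 3 `CCC1C(=O)N(C)c2cnc(Nc3ccc(S(=O)(=O)NC)cc3)nc2N1c1ccn(C)n1` is the next compound to be measured. It differs from compound 1 in one place: hydrogen in place of isopropyl on a saturated chain carbon bound to a sulfonamide nitrogen. Going by the values given here, no step between measured compounds that differ in one place is available to guide the expectation, and the change itself is a small trimming of a chain. For compound 3 the step is therefore expected to be modest, a 1.2-fold higher number from compound 1 to compound 3 (0.09 log units; within the scatter), leaning toward slightly weaker inhibition of growth. Compound 3 is expected to give about 9000 nM, within a range from 3500 nM to 25000 nM.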

Compound 3, concentration for 50% growth inhibition: 2890 nM
The estimate for compound 3 lay 3.1-fold (0.49 log units) above the measured number; the measured number lies below the stated range.
By their numbers in this assay, from the lowest: compound 2; then compound 3; then compound 1.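

In this assay, trimming isobutylsulfamoyl to methylsulfamoyl gives a 2.5-fold lower number from compound 1 to compound 3 (0.40 log units; beyond the scatter) and so shows that the group on the sulfonamide nitrogen matters for this read-out, with the shorter chain giving the stronger inhibition of growth of the two. Going by these compounds alone, this is the first difference that can be tied to a single change, and the direction runs toward stronger inhibition even though three carbons are removed. No measurement available here explains why this change has this effect.

With only isobutyl and methyl shown on the sulfonamide nitrogen, it remains open whether the number changes steadily with chain length or depends on the particular group. An ethyl chain, a longer chain carrying an amine, or one ending in a carboxylic acid could help separate these possibilities.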